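Moving bromine on the aryl group of compound 3

This account rests on a few compounds, and the source may have more. Where it says the series, first, only, none or still open, it means among the compounds named here.

Values so far in a functional assay on OVCAR-3 cells (Homo sapiens) for inhibition, read by MTT assay, with a stated time of 24 h (on this read-out lower numbers stand for stronger inhibition and higher numbers for weaker inhibition), are these:
compound 1 `CC1(C)[C@H]2CC[C@]1(C)N(Cc1cn(-c3cccc(F)c3)nn1)C(=O)C2` gives 430 nM
compound 2 `COc1ccccc1-n1cc(CN2C(=O)C[C@@H]3CC[C@@]2(C)C3(C)C)nn1` gives 140 nM
compound 3 `CC1(C)[C@H]2CC[C@]1(C)N(Cc1cn(-c3ccc(Br)cc3)nn1)C(=O)C2` gives 140 nM

Compound 3 at 140 nM is level with compound 2, and the pair shares the lowest number of the three, with compound 1 furthest off. Compound 4 `CC1(C)[C@H]2CC[C@]1(C)N(Cc1cn(-c3cccc(Br)c3)nn1)C(=O)C2` carries 3-bromophenyl in place of 4-bromophenyl on an aromatic nitrogen of a five-membered aromatic ring with 3 nitrogen. The change counts as 3-bromophenyl in place of 4-bromophenyl on an aromatic nitrogen and leaves the shared core untouched.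

All three measured steps alter the aryl group on that nitrogen. The series shows a 3.1-fold lower number from compound 1 to compound 3 (0.49 log units; beyond the scatter) and also a 3.1-fold lower number from compound 1 to compound 2 (0.49 log units; beyond the scatter) as modest steps, while the remaining pair gives no change at the digits printed from compound 2 to compound 3 (within the scatter) with no separation. Within the data shown here, compound 1 with 3-fluorophenyl is the nearest measured relative of 3-bromophenyl, but its halogen differs as well, and no measured pair moves bromine alone. Among the measured compounds shown here, a modest rise in this assay is therefore expected, no larger than those steps and possibly within the scatter. The estimate means a 1.6-fold higher number from compound 3 to compound 4 (0.22 log units; within the scatter) as the expected outcome. Compound 4 is expected at 230 nM within an estimated range of 90 nM to 550 nM in this series.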

Compound 4, half-maximal inhibitory concentration: 30 nM
Compound 4: middle estimate off by 7.7-fold (0.88 log units), on the high side; the measured number lies below the stated range.
By their numbers in this assay, from the lowest: compound 4; then compounds 2 and 3 (each within the scatter of the next); then compound 1.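

In this assay, among these compounds, moving bromine alone gives a 4.7-fold lower number from compound 3 to compound 4 (0.67 log units; beyond the scatter); 4-bromophenyl and 3-bromophenyl have the same atoms, so this pair shows that the place of the halogen on the aryl group matters by itself, which no earlier pair could isolate. With the halogen's place held, bromo in place of fluoro on an aromatic carbon gives a 14-fold lower number from compound 1 to compound 4 (1.16 log units; beyond the scatter), a large step, so the identity of the halogen also matters strongly here and 3-fluorophenyl proved a poor guide to 3-bromophenyl. The exchange of 2-methoxyphenyl for 3-bromophenyl gives a 4.7-fold lower number from compound 2 to compound 4 (0.67 log units; beyond the scatter), which separates compound 4 from compound 2 and compound 3, the pair that shared the lowest number before, and leaves compound 4 with the lowest number of the series.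

No supporting data at hand account for these steps. From the compounds shown here alone, whether chlorine, a nitrile or an amine in place of the bromine of 3-bromophenyl would keep a number as low as that of compound 4 remains open, as does whether a carboxylic acid would be tolerated there.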